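A few compounds are considered here, and "the series" means these few. Any claim that something is new, unique, unknown or untested is made for them only; others in the source may bear on it.

Measured so far:
- Compound 1 `COc1cc(CC(O)c2ccc(-c3ccc([N+](=O)[O-])cc3)cc2)c([N+](=O)[O-])cc1OC`: in an ADME assay on HeLa Rh cells (Homo sapiens) for cytotoxicity, read by microscopy (on this read-out lower numbers stand for higher toxicity in this test and higher numbers for lower toxicity in this test), compound 1 gives 21000 nM.
- Compound 2 `COc1cc(CC(O)c2ccc(-c3ccc(C=O)cc3)cc2)c([N+](=O)[O-])cc1OC`: in this assay compound 2 reaches only a limit of the assay, > 245000 nM.
- Compound 3 `COc1ccc(-c2ccc(C(O)Cc3cc(OC)c(OC)cc3[N+](=O)[O-])cc2)cc1`: in this assay compound 3 likewise reaches only a limit, > 244000 nM.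

Compound 1 is thus the only one of the three with an actual number; the other two sit at limits (the limit of > 244000 nM in this assay, at which 1 of the 3 values shown sits, (the limit of > 245000 nM in this assay, at which 1 of the 3 values shown sits)). Compound 4 `COc1cc(CC(O)c2ccc(-c3ccc(Br)cc3)cc2)c([N+](=O)[O-])cc1OC` differs from compound 1 in one place: bromo in place of nitro on an aromatic carbon. Among the compounds with values here, two measured steps bear on this, both replacing the same nitro: an at least 11-fold higher number from compound 1 to compound 2 (1.06 log units; beyond the scatter) and an at least 11-fold higher number from compound 1 to compound 3 (1.06 log units; beyond the scatter). Both point toward a higher number, so a large step in that direction is expected in this assay for compound 4 as well, a 5.7-fold higher number from compound 1 to compound 4 (0.76 log units; beyond the scatter). Compound 4 is therefore estimated at 120000 nM, between 30000 nM and 300000 nM.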

Compound 4, half-maximal cytotoxic concentration: 4300 nM
Compound 4: the middle estimate sits 28-fold (1.45 log units) above what was measured; measured number outside the range, below it.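

Replacing nitro need not raise the number at this position: with bromo in its place, this assay shows a 4.9-fold lower number from compound 1 to compound 4 (0.69 log units; beyond the scatter). The gap to the other two groups is wider, with an at least 56-fold lower number from compound 3 to compound 4 (1.75 log units; beyond the scatter) and an at least 56-fold lower number from compound 2 to compound 4 (1.75 log units; beyond the scatter). Compounds 2 and 3 give only limits of the assay, not numbers: the limit of > 244000 nM in this assay, at which 1 of the 4 values shown sits.

Going by these compounds, what stays open is how other groups at this position would read in this assay, such as chloro, an amine or a carboxylic acid. The compounds shown do not tell whether any of these would sit with bromo and nitro or with formyl and methoxy.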